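The source may report more compounds than this note shows. Statements on the series, on what has been measured and on what is new or still open speak of the compounds shown alone.

Measured compounds:
- compound 1 `CCC1C(=O)N(C)c2cnc(-n3ccc4cc(C(=O)NC(C)C)ccc43)nc2N1c1ccn(C)n1` — 125 nM
- compound 2 `CCCNC(=O)c1ccc2c(ccn2-c2ncc3c(n2)N(C2CCCC2)[C@H](CC)C(=O)N3C)c1` — 11.4 nM

In an assay for inhibition of serine/threonine-protein kinase PLK2 (Homo sapiens), read by FRET and Z'-LYTE, with a stated time of 1 h (a lower number here means a stronger inhibitor, a higher number a weaker inhibitor), compound 1 gives 125 nM. Compound 2 gives 11.4 nM in this assay; of the two numbers at hand, that of compound 1 is the higher, and the gap to compound 2 lies beyond the scatter. The two compounds differ in several places, so no single step can be read from them.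

Compound 3 `CCC1C(=O)N(C)c2cnc(-n3ccc4cc(C(N)=O)ccc43)nc2N1c1ccn(C)n1` has not been measured. It is compound 1 with hydrogen in place of isopropyl on an amide-type nitrogen. Among the compounds with values here, no measured pair shows this change, so its effect is open. The expectation is a small step, if any, in the weakening direction, not clearly beyond the scatter: compound 3 is estimated at 180 nM (range 60 nM to 600 nM). The step from compound 1 to compound 3 is thus expected to be a 1.4-fold higher number from compound 1 to compound 3 (0.16 log units; within the scatter).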

Compound 3, half-maximal inhibitory concentration: 384 nM
Compound 3: the middle estimate sits 2.1-fold (0.33 log units) below what was measured, within the range that was stated.
By their numbers in this assay, from the lowest: compound 2; then compound 1; then compound 3.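

In this assay, within the data shown here, the change from isopropylcarbamoyl to carbamoyl gives a 3.1-fold higher number from compound 1 to compound 3 (0.49 log units; beyond the scatter) and is the first single-place step available. The step is modest but beyond the scatter, so the number responds to what sits on this amide-type nitrogen, and the isopropyl compound is the stronger of this pair. No measurement bears on why the step has this size.

Still open, going by these compounds, is how the number moves with a methyl, a longer chain or a chain ending in an amine or a carboxylic acid on this nitrogen, and whether any of these would go below the number of compound 1. Compound 2 differs from compound 1 in several places, so it says nothing about this nitrogen on its own.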